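Vinyl in Place of Phenoxy: What to Expect

A few compounds are considered here, and "the series" means these few. Any claim that something is new, unique, unknown or untested is made for them only; others in the source may bear on it.

Compound 1 `CCOc1ccc(C2C(Oc3ccccc3)C(=O)N2c2cc(OC)c(OC)c(OC)c2)cc1`: 494 nM
Compound 2 `COc1ccc(C2C(C3CC3)C(=O)N2c2cc(OC)c(OC)c(OC)c2)cc1`: 156 nM
Compound 3 `CCSc1ccc(C2C(Oc3ccccc3)C(=O)N2c2cc(OC)c(OC)c(OC)c2)cc1`: 508 nM

All three were measured in a functional assay on HL-60 cells (Homo sapiens) for inhibition, read by resazurin assay, with a stated time of 72 h; on this read-out lower numbers stand for stronger inhibition and higher numbers for weaker inhibition. Among these three numbers compound 1 stands second highest; its nearest neighbour is compound 3, reached by a 1.0-fold higher number from compound 1 to compound 3 (0.01 log units; within the scatter), so the two are indistinguishable, while compound 2 sits furthest away with a clearly lower number.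

The next compound, compound 4 `C=CC1C(=O)N(c2cc(OC)c(OC)c(OC)c2)C1c1ccc(OCC)cc1`, differs from compound 1 in one place: vinyl in place of phenoxy on a saturated ring carbon.

Among the measured compounds shown here, only one measured step is available, and it concerns the ethoxy-to-ethylsulfanyl exchange on the aromatic carbon, not the ring carbon touched here; it therefore says little about this change. For the measured compounds named here, compound 2 carries a cyclopropyl at that ring carbon but also a methoxy instead of ethoxy on the aryl, so no single step links it to compound 1; its lower number can only be taken as a hint that a small hydrocarbon group at this position is compatible with a lower number in this assay.

On that basis compound 4 is expected to give 260 nM, within 100 nM to 700 nM, meaning an estimated 1.9-fold lower number from compound 1 to compound 4 (0.28 log units; within the scatter), with the uncertainty leaning wide.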

Compound 4, half-maximal inhibitory concentration: 35 nM
The estimate for compound 4 lay 7.4-fold (0.87 log units) above the measured number; measured number below the stated range.
By their numbers in this assay, from the lowest: compound 4; then compound 2; then compounds 1 and 3 (each within the scatter of the next).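

Replacing phenoxy, with 7 heavy atoms and an aromatic ring, by vinyl, with 2 heavy atoms and no ring, gives a 14-fold lower number from compound 1 to compound 4 (1.15 log units; beyond the scatter) in this assay. Among the compounds shown here, this is the first direct reading of the saturated ring carbon, and it shows that the aromatic ring of phenoxy is not needed there for a low number, since a far smaller group does much better in this one pair. The data at hand offer no measurement that explains the size of this step.

A single pair cannot separate the loss of the oxygen link from the loss of the ring, or show whether the double bond matters, so a saturated ethyl group, a methyl or an amine at this carbon would be needed to tell these apart. From the compounds shown here alone, it also remains open whether vinyl would give a similar step with the ethylsulfanyl group of compound 3 in place of ethoxy, and whether the result extends beyond this single cell read-out.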